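Replacing the amino group with trifluoromethyl on the shared core

The compounds below may be only part of what the source reports. "The series", "measured", "known", "first", "only" and "open" are said of these compounds alone.

Compound 2 `Cc1cc(N)c(S(C)(=O)=O)cc1C(=O)N=C(N)N` is one of two measured members of this series. In a functional assay for inhibition of sodium/hydrogen exchanger (Oryctolagus cuniculus) (a lower number here means a stronger inhibitor, a higher number a weaker inhibitor), compound 2 gives 16 nM, the higher of the two numbers; compound 1 `Cc1cc(SC(C)C)c(S(C)(=O)=O)cc1C(=O)N=C(N)N` gives 12 nM, and the two are within the usual scatter of each other. Within the data shown here, the one measured step, a 1.3-fold higher number from compound 1 to compound 2 (0.12 log units; within the scatter), shows that swapping a larger sulfur-linked group for amino at this position leaves the read-out essentially unchanged.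

Compound 3 `Cc1cc(C(F)(F)F)c(S(C)(=O)=O)cc1C(=O)N=C(N)N` carries the change (trifluoromethyl in place of amino on an aromatic carbon). Among the measured compounds shown here, the only step bearing on the position, from compound 1 to compound 2, was flat, so no shift beyond the scatter is expected from this further exchange; a wider range is kept, since no fluorinated group has yet been measured here.

Compound 3 is expected to give 15 nM in this assay, with a plausible range of 5 nM to 45 nM. The expected step of a 1.1-fold lower number from compound 2 to compound 3 (0.03 log units; within the scatter) is thus estimated to stay within the scatter.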

Compound 3, half-maximal inhibitory concentration: 37 nM
For compound 3 the middle estimate is 2.5-fold (0.39 log units) below the measured one; measured number inside the range.
By their numbers in this assay, from the lowest: compounds 1 and 2 (each within the scatter of the next); then compound 3.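

In this assay trifluoromethyl in place of amino gives a 2.3-fold higher number from compound 2 to compound 3 (0.36 log units; beyond the scatter) and trifluoromethyl in place of isopropylsulfanyl gives a 3.1-fold higher number from compound 1 to compound 3 (0.49 log units; beyond the scatter) on the same aromatic carbon. The position therefore does respond to its substituent, which the flat step a 1.3-fold higher number from compound 1 to compound 2 (0.12 log units; within the scatter) alone did not show, though the shifts remain modest. Of the three groups compared here, only trifluoromethyl stands apart from the others, and no measurement available accounts for this difference.

Whether the shift is specific to trifluoromethyl remains open, as the shown compounds include no methyl, chlorine, methoxy or nitrile at this position. A single fluorinated group also cannot show whether other fluorinated groups, such as trifluoromethoxy, would behave in the same way.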